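Ribose-bearing purine series: methoxyphenyl to trifluorophenyl arm

The compounds below may be only part of what the source reports. "The series", "measured", "known", "first", "only" and "open" are said of these compounds alone.

Measured so far:
compound 1 `COc1ccccc1CNc1ncnc2c1ncn2[C@@H]1O[C@H](CO)[C@@H](O)[C@H]1O` — 2300 nM
compound 2 `OC[C@H]1O[C@@H](n2cnc3c(NCc4cc(F)cc(F)c4)ncnc32)C(O)C1O` — 9100 nM

In a functional assay on HL-60 cells (Homo sapiens) for antiproliferative activity, with a stated time of 72 h (on this read-out higher numbers stand for weaker inhibition and lower numbers for stronger inhibition), compound 1 gives 2300 nM, the lowest of the two numbers; compound 2 gives 9100 nM, a gap beyond the scatter. Within the data shown here, no pair differing in one place has been measured, and compound 2 differs from compound 1 in more than one place, so it offers only a loose hint. Compound 3 `OC[C@H]1O[C@@H](n2cnc3c(NCc4c(F)ccc(F)c4F)ncnc32)[C@H](O)[C@@H]1O` differs from compound 1 by 2,3,6-trifluorophenyl in place of 2-methoxyphenyl on a saturated chain carbon bound to a nitrogen on an aromatic ring. The step of a 2.2-fold higher number from compound 1 to compound 3 (0.34 log units; beyond the scatter) is expected to be modest, toward weaker inhibition. Compound 3 is estimated at 5000 nM, within 1500 nM to 16000 nM.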

Compound 3, half-maximal inhibitory concentration: 13000 nM
Compound 3: the middle estimate sits 2.6-fold (0.41 log units) below what was measured; low and high end bracket the measured number.
By their numbers in this assay, from the lowest: compound 1; then compounds 2 and 3 (each within the scatter of the next).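

In this assay, among these compounds, 2,3,6-trifluorophenyl in place of 2-methoxyphenyl on a saturated chain carbon bound to a nitrogen on an aromatic ring gives a 5.7-fold higher number from compound 1 to compound 3 (0.75 log units; beyond the scatter), the first step read between compounds differing in one place. This position therefore responds to an exchange of the aryl group, here toward weaker inhibition. No available measurement bears on the reason for this step. As far as these compounds go, it remains open whether the shift follows from losing the methoxy group or from gaining the fluorines. An unsubstituted phenyl or an aminophenyl at this position would help separate the two.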